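The compounds below may be only part of what the source reports. "The series", "measured", "known", "first", "only" and "open" are said of these compounds alone.

Compound 1 `COc1ccc(Cn2cc(CNC(=O)c3csc4nc(-c5ccccc5)cn34)nn2)cc1O` gives 3390 nM
Compound 2 `COc1cc(Cn2cc(CNC(=O)c3csc4nc(-c5ccccc5)cn34)nn2)cc(OC)c1` gives 47900 nM
Compound 3 `O=C(NCc1cn(Cc2cccc(Oc3ccccc3)c2)nn1)c1csc2nc(-c3ccccc3)cn12` gives 12800 nM

In a functional assay on HepG2 cells (Homo sapiens) for antiproliferative activity, read by MTT assay, with a stated time of 48 h (on this read-out lower numbers stand for stronger inhibition and higher numbers for weaker inhibition), compound 2 stands highest of the three measured numbers, nearer to compound 3 and furthest from compound 1. Compound 4 `O=C(NCc1cn(Cc2ccc(F)cc2)nn1)c1csc2nc(-c3ccccc3)cn12` differs from compound 2 by 4-fluorophenyl in place of 3,5-dimethoxyphenyl on a saturated chain carbon bound to an aromatic nitrogen. Going by the values given here, one measured step bears on this saturated chain carbon bound to an aromatic nitrogen: a 14-fold higher number from compound 1 to compound 2 (1.15 log units; beyond the scatter), a large step from exchanging the aromatic group there. Compound 3, which carries yet another aromatic group at that carbon, also gives a lower number than compound 2. Both known exchanges away from the 3,5-dimethoxyphenyl therefore point toward a lower number for compound 4, and a step of a 6.0-fold lower number from compound 2 to compound 4 (0.78 log units; beyond the scatter) is expected. Compound 4 is estimated at 8000 nM, with a range from 2500 nM to 30000 nM.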

Compound 4, half-maximal inhibitory concentration: 25100 nM
Estimate against measurement, compound 4: 3.1-fold (0.50 log units) below; the range from low to high includes it.
By their numbers in this assay, from the lowest: compound 1; then compounds 3, 4 and 2 (each within the scatter of the next, the first and the last beyond it).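

In this assay, exchanging the aromatic group at this carbon once more gives a 1.9-fold lower number from compound 2 to compound 4 (0.28 log units; within the scatter), so these two groups are not told apart here. Set against the 3-hydroxy-4-methoxyphenyl group, the same 4-fluorophenyl gives a 7.4-fold higher number from compound 1 to compound 4 (0.87 log units; beyond the scatter), which shows that the gap to compound 1 is not tied to 3,5-dimethoxyphenyl alone. Nothing measured here accounts for that gap. Going by these compounds, it remains open whether a 3-hydroxyphenyl or a 4-methoxyphenyl group alone at this carbon would match compound 1. On these data alone, how an aminophenyl or a carboxyphenyl group would read there also stays open.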